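The source may hold more compounds than are shown below. What is called first, only, known or untested is meant among the compounds shown, and "the series" means these compounds.

Three compounds share one core and differ only in the aryl group attached to it. Compound 1 `NS(=O)(=O)c1ccc(-c2nc(C(c3ccc(F)cc3)c3ccc(F)cc3)sc2CC(=O)O)cc1` returns only a limit in an in vitro functional assay on HEK285-7 cells for antagonist activity at prostaglandin D2 receptor 2 (Homo sapiens), read by BRET and beta-arrestin recruitment (on this read-out lower numbers stand for stronger inhibition and higher numbers for weaker inhibition), namely > 100000 nM, and that limit is the limit of > 100000 nM in this assay, at which 1 of the 3 values shown sits. Compound 2 `CS(=O)(=O)Nc1cccc(-c2nc(C(c3ccc(F)cc3)c3ccc(F)cc3)sc2CC(=O)O)c1` gives a number in this assay, 370 nM, so the change from compound 1 to compound 2 is an at least 270-fold lower number from compound 1 to compound 2 (2.43 log units; beyond the scatter). Compound 3 `O=C(O)Cc1sc(C(c2ccc(F)cc2)c2ccc(F)cc2)nc1-c1ccnc(F)c1` gives 4.7 nM in this assay, the lowest of the two numbers shown; its nearest neighbour is compound 2, the gap being a 79-fold lower number from compound 2 to compound 3 (1.90 log units; beyond the scatter), and from compound 1 the step is an at least 21000-fold lower number from compound 1 to compound 3 (4.32 log units; beyond the scatter).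

Compound 4 `O=C(O)Cc1sc(C(c2ccc(F)cc2)c2ccc(F)cc2)nc1-c1ccnc(N2CCCC2)c1` keeps the pyridine of compound 3 and alters a single substituent on it: pyrrolidin-1-yl in place of fluoro on an aromatic carbon. None of the three measured steps touches this position; each exchanges the whole aryl group, so they give no direct guide to the size of this step. The account therefore expects for compound 4 a step of a 2.6-fold higher number from compound 3 to compound 4 (0.41 log units; beyond the scatter), a small change in either direction. The estimate for compound 4 in this assay is 12 nM, within 2 nM to 70 nM.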

Compound 4, half-maximal inhibitory concentration: > 100000 nM
Compound 4 was reported as a limit; the forecaster's own chance of this, stated with the estimate: 3%; at least 8300-fold (3.92 log units) between middle value and limit.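

The position next to the ring nitrogen proves highly sensitive: with the rest of the molecule unchanged, pyrrolidin-1-yl in place of fluoro gives an at least 21000-fold higher number from compound 3 to compound 4 (4.32 log units; beyond the scatter), whereas each earlier step exchanged the whole aryl group. The 2-(pyrrolidin-1-yl)pyridin-4-yl group also compares poorly with the 3-(methanesulfonamido)phenyl group, with an at least 270-fold higher number from compound 2 to compound 4 (2.43 log units; beyond the scatter). Compound 4 gives only a limit, so its step to compound 1 cannot be read, and that limit is a shared one: the limit of > 100000 nM in this assay, at which 2 of the 4 values shown sit.

The compounds shown leave open where between fluoro and pyrrolidin-1-yl the inhibition is lost, since they do not tell how a methoxy group or an open-chain amine such as dimethylamino would read at this carbon. On these data alone, because the value of compound 4 is a limit, the full size of the step from fluoro also stays unknown.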